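Methoxy to Cyano at the 4-Position: What to Expect

A few compounds are considered here, and "the series" means these few. Any claim that something is new, unique, unknown or untested is made for them only; others in the source may bear on it.

Measured so far:
compound 1 `Cc1ccc(S(=O)(=O)c2cnc3cc(Cl)ccc3c2N2CCC(C)CC2)cc1F`: 85%
compound 2 `COc1ccc(S(=O)(=O)c2cnc3cc(F)ccc3c2N2CCC(C)CC2)cc1`: 90%

In an assay on isolated protein for displacement of a labelled ligand from metabotropic glutamate receptor 5 (Homo sapiens), with a stated time of 60 min, tested at 1 uM (a lower number here means less inhibition, a higher number more inhibition at the concentration tested (going by the name of the read-out)), compound 2 gives 90% and compound 1 gives 85%. The two numbers differ by an amount within the usual scatter, so neither compound can be set above the other; both show strong inhibition at the concentration tested. Among the compounds with values here, no step between two measured compounds that differ in one place is available, so the effect of a single change on the shared core has not been seen.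

Compound 3 `CC1CCN(c2c(S(=O)(=O)c3ccc(C#N)cc3)cnc3cc(F)ccc23)CC1` differs from compound 2 by the change (cyano in place of methoxy on an aromatic carbon). Because in this assay compound 2 gives 90% and compound 1 gives 85%, both high numbers, the step from compound 2 to compound 3 is expected to be small, if anything a slight decrease, and probably not beyond the scatter: a number 10 percentage points lower from compound 2 to compound 3 (within the scatter). Compound 3 is therefore estimated at 80%, within a range of 55% to 95%.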

Compound 3, a percentage reported as inhibition, at one concentration (the size of the read-out at that concentration, not a potency): 83%
Estimate against measurement, compound 3: 3 percentage points below; the measured number falls inside the stated range.
By their numbers in this assay, from the lowest: compounds 3, 1 and 2 (each within the scatter of the next).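

Within the data shown here, the change from 4-methoxyphenyl to 4-cyanophenyl gives the first step between two compounds that differ in one place, and in this assay it reads as follows: a number 7 percentage points lower from compound 2 to compound 3 (within the scatter). This position, on an aromatic carbon para to a large group, therefore takes cyano in place of methoxy without a difference that can be told from the scatter, and inhibition at the concentration tested is high on both sides of the step. Nothing measured here gives a reason for this result.

The compounds shown leave open whether an amine, a carboxylic acid or a longer chain such as butoxy would be taken equally well at this position. They also leave open whether compound 2 and compound 3 would still match in potency, since a reading at one concentration does not give a potency.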